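A few compounds are considered here, and "the series" means these few. Any claim that something is new, unique, unknown or untested is made for them only; others in the source may bear on it.

In a functional assay on HCT-116 cells (Homo sapiens) for inhibition, read by sulforhodamine B assay, with a stated time of 48 h, tested at 100 uM (a lower number here means a stronger effect, a higher number a weaker effect of the compound at the concentration tested), compound 1 `O=C(Nc1cccc(-n2cc(-c3ccncc3)c(-c3cc(O)cc(Cl)c3)n2)c1)Nc1ccc(Cl)c(C(F)(F)F)c1` gives -57%. Among the two compounds with a number, compound 1 stands highest, but its only neighbour lies close: compound 2 `O=C(Nc1cccc(-n2cc(-c3ccncc3)c(-c3cc(O)cc(Cl)c3)n2)c1)Nc1ccc(Cl)c(Cl)c1` gives -61%, and the step of a number 4 percentage points lower from compound 1 to compound 2 (within the scatter) is within the scatter, so the two cannot be told apart on these numbers. Compound 3 `COc1cc(Cl)cc(-c2nn(-c3cccc(NC(=O)Nc4ccc(Cl)c(C(F)(F)F)c4)c3)cc2-c2ccncc2)c1` has not yet been tested in this assay. It differs from compound 1 in one place: methyl in place of hydrogen on an oxygen on an aromatic ring Cut one bond further out, the change reads hydroxy to methoxy, that is 3-chloro-5-hydroxyphenyl to 3-chloro-5-methoxyphenyl. Going by the values given here, no measured step touches this oxygen; the single step available, a number 4 percentage points lower from compound 1 to compound 2 (within the scatter), concerns a chloro replacing a trifluoromethyl and does not bear on a methyl entering here. With nothing to go on beyond the closeness of compounds 1 and 2, the expectation is a step of a number 7 percentage points higher from compound 1 to compound 3 (within the scatter) that stays within the scatter, although the uncertainty is wide. Compound 3 is therefore estimated at -50%, with a range from -80% to -15%.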

Compound 3, a percentage reported as activity, at one concentration (the size of the read-out at that concentration, not a potency): -94%
Estimate against measurement, compound 3: 44 percentage points above, outside the stated range (below it).
By their numbers in this assay, from the lowest: compound 3; then compounds 2 and 1 (each within the scatter of the next).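

In this assay, going by these compounds alone, the methyl on the oxygen gives a number 37 percentage points lower from compound 1 to compound 3 (beyond the scatter) and so changes the read-out clearly, whereas the only earlier step, a number 4 percentage points lower from compound 1 to compound 2 (within the scatter), left the two compounds indistinguishable. This oxygen on the aromatic ring is therefore a place where a single added carbon has a large effect on the read-out, and the hydrogen on it is not required for the effect at the concentration tested, since the methoxy compound 3 gives the lower number, which here means the stronger effect. Nothing among the data shown explains this gain, so the reason for it remains unknown.

Going by these compounds, what stays open is whether an ethyl or a longer chain on this oxygen would go further than methyl, or whether an amine in place of the oxygen would keep the effect. Also open, on these data alone, is whether the same methyl would have a comparable effect on compound 2, which carries chloro in place of trifluoromethyl, and whether the stronger effect seen at the concentration tested would also appear at other concentrations.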